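Swapping trifluoromethyl for chloro on a quinazoline thiosemicarbazide

This account rests on a few compounds, and the source may have more. Where it says the series, first, only, none or still open, it means among the compounds named here.

Measured so far:
compound 1 `COc1cc2ncnc(NNC(=S)NC(=O)c3ccccc3C)c2cc1OC` gives 11400 nM
compound 2 `O=C(NC(=S)NNc1ncnc2ccccc12)c1ccc(C(F)(F)F)cc1` gives 7920 nM
compound 3 `COc1cc2ncnc(NNC(=S)NC(=O)c3ccc(F)cc3)c2cc1OC` gives 4530 nM

All three were tested in a functional assay on KB cells (Homo sapiens) for cytotoxicity, read by MTT assay, with a stated time of 72 h; a lower number here means a stronger inhibitor, a higher number a weaker inhibitor. Compound 2 stands close to both of the others: its number differs from compound 1 and from compound 3 by less than the usual scatter, so none of the three can be told apart from compound 2 with confidence. Going by the values given here, the only step measured between two compounds that differ in a single place is a 2.5-fold lower number from compound 1 to compound 3 (0.40 log units; beyond the scatter), where a 4-fluorophenyl took the place of a 2-methylphenyl on the carbonyl carbon.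

Compound 4 `O=C(NC(=S)NNc1ncnc2ccccc12)c1ccc(Cl)cc1` has not yet been measured. It differs from compound 2 in one place: chloro in place of trifluoromethyl on an aromatic carbon. Among the compounds with values here, no measured step touches this part of the structure, and the one step available concerns a different position and a different pair of groups, so it offers only a rough sense of how much a single change of this kind has moved the number here, and that movement was modest.

With nothing pointing strongly either way, the expected step is a 1.2-fold lower number from compound 2 to compound 4 (0.09 log units; within the scatter), within the scatter. Compound 4 is therefore estimated at 6500 nM, with a range from 3000 nM to 14000 nM.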

Compound 4, half-maximal inhibitory concentration: 3940 nM
Compound 4: middle estimate off by 1.6-fold (0.22 log units), on the high side, within the range that was stated.
By their numbers in this assay, from the lowest: compounds 4, 3, 2 and 1 (each within the scatter of the next, the first and the last beyond it).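

Going by these compounds alone, compound 2 and compound 4 give the first measured step at this place on the ring, an aromatic carbon para to a large group. In this assay, replacing trifluoromethyl with chloro gives a 2.0-fold lower number from compound 2 to compound 4 (0.30 log units; within the scatter) and so does not separate the two compounds with confidence, even though a group of 4 heavy atoms gives way to a single chlorine atom. At this place, then, the pair shows that this particular exchange leaves the cytotoxicity reading in the same band, and nothing measured here explains why the two groups read alike.

Within the data shown here, the pair covers only two groups at this place, so it remains open how the number would respond to a different kind of group there, such as an amine, a carboxylic acid or a longer carbon chain. From the compounds shown here alone, it also remains open whether the same exchange would give a similar step on the core of compound 1 and compound 3, which carries two methoxy groups that compound 2 and compound 4 lack.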